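A few compounds are considered here, and "the series" means these few. Any claim that something is new, unique, unknown or untested is made for them only; others in the source may bear on it.

Measured so far in an ADME assay on microsomes from liver (Homo sapiens) for metabolic stability, read by LC-MS, tested at 1 uM; a higher number here means faster removal of the compound, a lower number slower removal:
compound 1 `c1cc([C@H]2CC[C@]3(CC2)OOC2(O3)C3CC4CC(C3)CC2C4)ccc1OCCCNC1CCOCC1`: 10 mL.min-1.g-1
compound 2 `N[C@H]1CC[C@H](Oc2ccc([C@H]3CC[C@]4(CC3)OOC3(O4)C4CC5CC(C4)CC3C5)cc2)CC1`: < 7 mL.min-1.g-1, a limit of the assay
compound 3 `c1cc([C@H]2CC[C@]3(CC2)OOC2(O3)C3CC4CC(C3)CC2C4)ccc1OCCOC1CCNCC1`: < 7 mL.min-1.g-1, likewise a limit

For the measured compounds named here, compound 1 holds the only number in this assay; the other two values are limits, and the limit of < 7 mL.min-1.g-1 in this assay, at which 2 of the 3 values shown sit, marks where they sit. The measured steps both run downward from compound 1: an at least 1.4-fold lower number from compound 1 to compound 2 (0.15 log units; that floor lies within the scatter) and an at least 1.4-fold lower number from compound 1 to compound 3 (0.15 log units; that floor lies within the scatter), each with a floor that lies within the scatter. Between the two limits, a step that the two limits leave unreadable from compound 2 to compound 3 gives no readable size.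

Compound 4 `NCCS(=O)(=O)CCOc1ccc([C@H]2CC[C@]3(CC2)OOC2(O3)C3CC4CC(C3)CC2C4)cc1` differs from compound 1 by (2-aminoethyl)sulfonyl in place of ((oxan-4-yl)amino)methyl on a saturated chain carbon, two bonds along the chain from an oxygen on an aromatic ring. The steps from compound 1 bear on it in that both replacements of the oxan-4-yl amine end at the limit; the new change is of a similar kind, so a move toward the limit is the expectation, though the floor of both steps leaves the size uncertain. Compound 4 is therefore expected at 7 mL.min-1.g-1, between 3.5 mL.min-1.g-1 and 14 mL.min-1.g-1, a step of a 1.4-fold lower number from compound 1 to compound 4 (0.15 log units; within the scatter) expected from compound 1.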

Compound 4, intrinsic clearance in microsomes: 9 mL.min-1.g-1
Compound 4: the middle estimate sits 1.3-fold (0.11 log units) below what was measured; low and high end bracket the measured number.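

With (2-aminoethyl)sulfonyl in place of ((oxan-4-yl)amino)methyl on a saturated chain carbon, two bonds along the chain from an oxygen on an aromatic ring, this assay shows a 1.1-fold lower number from compound 1 to compound 4 (0.05 log units; within the scatter) and so no readable change at this place. Losing the oxan-4-yl ring here therefore does not by itself bring a compound to the limit, since compound 4 holds a measured number. Against the two compounds at a limit only floors can be read, an at least 1.2-fold higher number from compound 3 to compound 4 (0.10 log units; that floor lies within the scatter) and an at least 1.2-fold higher number from compound 2 to compound 4 (0.10 log units; that floor lies within the scatter) both being steps with no upper size, as those values are limits and not numbers: the limit of < 7 mL.min-1.g-1 in this assay, at which 2 of the 4 values shown sit.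

From the compounds shown here alone, whether a sulfonamide or a longer chain carrying the terminal amine would keep compound 4's standing remains open. Going by these compounds, the true distance of compound 2 and compound 3 from compound 4 also stays unknown.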